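Trifluoromethyl in place of methyl: two cores compared

A few compounds are considered here, and "the series" means these few. Any claim that something is new, unique, unknown or untested is made for them only; others in the source may bear on it.

Three compounds are measured in a functional assay on KBVIN cells (Homo sapiens) for antiproliferative activity, read by sulforhodamine B assay, with a stated time of 72 h; a lower number here means a stronger inhibitor of growth, a higher number a weaker inhibitor of growth. Compound 1 `Cc1cc(=O)oc2cc(SCc3cccc(C(F)(F)F)c3)ccc12` reports a limit of the assay, > 28500 nM, and not a number. Compound 2 `Cc1cccc(CSc2ccc3c(C)cc(=O)oc3c2)c1` likewise reports only a limit, > 33700 nM. Among the compounds with values here, compound 3 `CCc1cc(=O)c2ccc(OCc3cccc(C)c3)c(C)c2o1` is the one compound with a number, giving 24900 nM in this assay. The step that the two limits leave unreadable from compound 2 to compound 1 cannot be read, as both ends sit at a limit: the limit of > 33700 nM in this assay, at which 1 of the 3 values shown sits, and (the limit of > 28500 nM in this assay, at which 1 of the 3 values shown sits).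

Compound 4 `CCc1cc(=O)c2ccc(OCc3cccc(C(F)(F)F)c3)c(C)c2o1` has not yet been measured. The difference between the core of compound 3 and the core of compound 2 is not broken down here. The change from compound 3 to compound 4 is trifluoromethyl in place of methyl on an aromatic carbon, and the change from compound 2 to compound 1 is trifluoromethyl in place of methyl on an aromatic carbon; the two place descriptions agree word for word, so this is the same change made on two cores, occurring twice in all among the compounds shown.

Since the earlier step is unreadable, the expectation for compound 4 rests on compound 3 and its value 24900 nM, with no measured size of the change to lean on. The step of a 1.0-fold higher number from compound 3 to compound 4 (0.00 log units; within the scatter) is expected to be small, within the usual scatter, and the estimate carries a wide range. Compound 4 is estimated at 25000 nM in this assay, from 8000 nM to 80000 nM, with a real chance that only a limit is reported.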

Compound 4, concentration for 50% growth inhibition: > 27600 nM
Compound 4: no number, only a limit (the forecaster's own chance of this, stated with the estimate: 45%); middle value at least 1.1-fold (0.04 log units) from the limit.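

In this assay, trifluoromethyl in place of methyl on the core of compound 3 gives an at least 1.1-fold higher number from compound 3 to compound 4 (0.04 log units; that floor lies within the scatter). Going by these compounds, compound 4 reports a limit and not a number, so this step is only a floor, and its true size stays unknown: the limit of > 27600 nM in this assay, at which 1 of the 4 values shown sits. Within the data shown here, the same change on the other core cannot be read, as compound 2 and compound 1 both report limits, so the two cores offer no pair of sizes to compare, and the series shows neither that the step carries over from one core to the other nor that it differs; the only shared observation is that both trifluoromethyl compounds, compound 1 and compound 4, end at a limit.

Among these compounds, compound 3 is the only compound here with a number, and the core of compound 3 and the core of compound 2 differ in more than one place, so what the core alone contributes stays open. Also open, on these data alone, is whether an amine, a carboxylic acid or a longer chain on the same aromatic carbon would give a number in this assay on either core.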